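The source may report more compounds than this note shows. Statements on the series, on what has been measured and on what is new or still open speak of the compounds shown alone.

In a functional assay on HCT-116 cells (Homo sapiens) for inhibition, read by MTT assay, with a stated time of 72 h (on this read-out higher numbers stand for weaker inhibition of growth and lower numbers for stronger inhibition of growth), compound 1 `CCOC(=O)/C=C/c1ccncc1-c1ccc2[nH]ccc2c1` gives 4830 nM and compound 2 `CCOC(=O)/C=C/c1ccncc1-c1ccc2c(ccn2C)c1` gives 210 nM, the lower of the two numbers. For the measured compounds named here, the only measured step, a 23-fold lower number from compound 1 to compound 2 (1.36 log units; beyond the scatter), is methyl in place of hydrogen on an aromatic nitrogen. Compound 3 `Cn1ccc2cc(-c3cnccc3/C=C/C(=O)O)ccc21` keeps that methyl and differs from compound 2 elsewhere: hydrogen in place of ethyl on an oxygen next to a carbonyl group. In words, this is hydrogen in place of ethyl on an oxygen next to a carbonyl group, turning ethoxycarbonyl into carboxy. Going by the values given here, no measured pair tests this change, so that one step bears on it only loosely, showing that a single small change can move the number beyond the scatter. The direction is a judgement, not a measured trend: a large move toward a higher number, meaning weaker inhibition of growth, is expected. The estimated size is a 9.5-fold higher number from compound 2 to compound 3 (0.98 log units; beyond the scatter). For compound 3, the expected value is 2000 nM, with an estimated range from 300 nM to 15000 nM.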

Compound 3, concentration for 50% growth inhibition: 7260 nM
The estimate for compound 3 lay 3.6-fold (0.56 log units) below the measured number; measured number inside the range.
By their numbers in this assay, from the lowest: compound 2; then compounds 1 and 3 (each within the scatter of the next).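

In this assay, hydrogen in place of ethyl on the oxygen next to the carbonyl group, which turns ethoxycarbonyl into carboxy, gives a 35-fold higher number from compound 2 to compound 3 (1.54 log units; beyond the scatter) and shows that this end of the molecule strongly affects the read-out. Compound 3 keeps the methyl on the aromatic nitrogen, so that methyl alone does not preserve the low number seen for compound 2. Nothing measured here explains why this change has so large an effect.

On these data alone, it remains open whether ethyl itself matters or whether other groups on that oxygen would serve as well, such as a methyl or a longer chain, and an amide in place of the ester is also untested here. As far as these compounds go, the effect of the carboxy group with hydrogen on the aromatic nitrogen, as in compound 1, also remains unknown.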